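This account rests on a few compounds, and the source may have more. Where it says the series, first, only, none or still open, it means among the compounds named here.

Compounds measured so far:
- compound 1, `O=C(Nc1ccc(Oc2ccnc3[nH]ccc23)c(F)c1)c1cc2cccnc2n(-c2ccccc2)c1=O`: 190 nM
- compound 2, `O=C(Nc1ccc(Oc2ccnc3[nH]ccc23)c(F)c1)c1cc2cccnc2n(-c2ccc(F)c(Cl)c2)c1=O`: 630 nM
- compound 3, `O=C(Nc1ccc(Oc2ccnc3[nH]ccc23)c(F)c1)c1cc2cccnc2n(-c2ccc(C(F)(F)F)cc2Cl)c1=O`: 1020 nM

In a functional assay on A549 cells (Homo sapiens) for antiproliferative activity, read by MTT assay, with a stated time of 72 h (on this read-out lower numbers stand for stronger inhibition and higher numbers for weaker inhibition), compound 1 stands with the lowest number of the three. Its nearest neighbour is compound 2, reached by a 3.3-fold higher number from compound 1 to compound 2 (0.52 log units; beyond the scatter), and the furthest is compound 3, reached by a 5.4-fold higher number from compound 1 to compound 3 (0.73 log units; beyond the scatter). Both of those steps swapped the group on the aromatic nitrogen of the shared core and both lie beyond the scatter.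

Compound 4, `Cn1ccc2c(Oc3ccc(NC(=O)c4cc5cccnc5n(-c5ccccc5)c4=O)cc3F)ccnc21`, differs from compound 1 elsewhere: methyl in place of hydrogen on an aromatic nitrogen. This change touches a different part of the molecule from the two measured steps, so neither of them bears on it directly; they only show that the core tolerates small changes with modest losses. Among the compounds with values here, there is no measured pair that alters this hydrogen, so the expectation rests on the change itself and carries wide uncertainty.

For compound 4 the expected result in this assay is a higher number than compound 1, a step of a 7.9-fold higher number from compound 1 to compound 4 (0.90 log units; beyond the scatter), giving an estimate of 1500 nM with a range from 200 nM to 12000 nM.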

Compound 4, half-maximal inhibitory concentration: 430 nM
Beside the measured number, compound 4's estimate is 3.5-fold (0.54 log units) above it; low and high end bracket the measured number.
By their numbers in this assay, from the lowest: compound 1; then compounds 4, 2 and 3 (each within the scatter of the next, the first and the last beyond it).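

The earlier compounds shown here changed only the group on one aromatic nitrogen, whereas compound 4 gives the first view of the other one, in the five-membered ring of the shared core. In this assay, methyl in place of hydrogen there gives a 2.3-fold higher number from compound 1 to compound 4 (0.35 log units; beyond the scatter) and so costs some activity, though the step is modest and the hydrogen is not needed for a measurable effect on these cells. Nothing available explains why this small addition raises the number.

Still open, from the compounds shown here alone, is how this nitrogen responds to other groups, such as ethyl or a longer chain ending in an amine, which would show whether the loss grows with the size of the group. It is also unknown whether methyl at this position would have a similar effect on compound 2 and compound 3, which carry substituted phenyl groups.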